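This account rests on a few compounds, and the source may have more. Where it says the series, first, only, none or still open, it means among the compounds named here.

Three esters built on one shared core have been tested in a functional assay on the whole organism (strain Sprague-Dawley CD) for inhibition, with Rattus norvegicus as the target, read by paw edema, at a dose of 30 mg/kg by the intraperitoneal route; a higher number here means a stronger effect of the compound at the dose given, a lower number a weaker effect. Compound 1, with structure `CCOC(=O)C(=O)Nc1cccccc1=O`, gives 84%. Compound 2, `CC(C)OC(=O)C(=O)Nc1cccccc1=O`, gives 96%. Compound 3, `CC(C)(C)OC(=O)C(=O)Nc1cccccc1=O`, gives 79%. Compound 3 stands at the low end of the three numbers, but its gap to compound 1 is small: a number 5 percentage points lower from compound 1 to compound 3 (within the scatter) lies within the scatter, whereas a number 17 percentage points lower from compound 2 to compound 3 (beyond the scatter) lies beyond it, as does a number 12 percentage points higher from compound 1 to compound 2 (beyond the scatter).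

Compound 4, `CCCCCOC(=O)C(=O)Nc1cccccc1=O`, is the next step: pentyl in place of tert-butyl on an oxygen next to a carbonyl group. The oxygen next to a carbonyl group again carries an unbranched chain, as it does in compound 1. The measured step that bears most on this is a number 5 percentage points lower from compound 1 to compound 3 (within the scatter), which shows that exchanging ethyl for tert-butyl on that oxygen changed little. Isopropyl in compound 2 gave a higher number, but no measured step compares a straight chain longer than ethyl with any of these groups. The step of a number 5 percentage points higher from compound 3 to compound 4 (within the scatter) is therefore expected to stay within the scatter. The estimate for compound 4 in this assay is 84%, with a range from 68% to 96%.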

Compound 4, a percentage reported as inhibition, in the whole organism at one dose (the size of the read-out at that dose, not a potency): 57%
Compound 4: the middle estimate sits 27 percentage points above what was measured; the whole stated range lies above it.
By their numbers in this assay, from the lowest: compound 4; then compounds 3 and 1 (each within the scatter of the next); then compound 2.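

In this assay, pentyl on an oxygen next to a carbonyl group gives the lowest number of the four compounds: a number 22 percentage points lower from compound 3 to compound 4 (beyond the scatter), a number 39 percentage points lower from compound 2 to compound 4 (beyond the scatter), and a number 27 percentage points lower from compound 1 to compound 4 (beyond the scatter). The group on this oxygen therefore matters more than the near match between ethyl in compound 1 and tert-butyl in compound 3 suggested, and a chain that is simply unbranched does not keep the effect, as ethyl does and pentyl does not. No measurement shown gives a reason for this drop.

Propyl and butyl chains are not among these compounds, so it remains open whether the number falls gradually or abruptly between ethyl and pentyl. Also open, as far as these compounds go, is how a longer chain such as hexyl, or a benzyl group, would behave on the same oxygen.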